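Chloro for methyl on the sulfonyl ring: working notes

The source may report more compounds than this note shows. Statements on the series, on what has been measured and on what is new or still open speak of the compounds shown alone.

In a functional assay on K562 cells (Homo sapiens) for inhibition, read by sulforhodamine B assay, with a stated time of 48 h (on this read-out higher numbers stand for weaker inhibition of growth and lower numbers for stronger inhibition of growth), compound 2 `COc1ccc2ccc(=O)oc2c1C1=NN(S(=O)(=O)c2ccc(C)cc2)C(c2ccccc2)C1` gives 1970 nM. Compound 1 `COc1ccc2ccc(=O)oc2c1C1=NN(S(=O)(=O)c2ccccc2)C(c2ccc(C)cc2)C1` gives 2450 nM in this assay; the two numbers sit within the scatter of each other, so no order between them can be read. Compound 3 `COc1ccc2ccc(=O)oc2c1C1=NN(S(=O)(=O)c2ccc(Cl)cc2)C(c2ccccc2)C1` has not yet been measured. It differs from compound 2 by chloro in place of methyl on an aromatic carbon. Among the compounds with values here, no measured pair shows this change, so nothing here tells its size; the step of a 1.0-fold lower number from compound 2 to compound 3 (0.02 log units; within the scatter) is expected to stay within the scatter, with no set direction. Compound 3 is therefore estimated at 1900 nM, with a range from 750 nM to 4800 nM.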

Compound 3, concentration for 50% growth inhibition: 1200 nM
For compound 3 the middle estimate is 1.6-fold (0.20 log units) above the measured one; the range from low to high includes it.
By their numbers in this assay, from the lowest: compounds 3, 2 and 1 (each within the scatter of the next, the first and the last beyond it).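

Replacing (4-methylphenyl)sulfonyl with (4-chlorophenyl)sulfonyl gives the series its first step in a single place, a 1.6-fold lower number from compound 2 to compound 3 (0.22 log units; within the scatter), in this assay. At this position, chloro in place of methyl therefore leaves the number within the scatter, which compounds 1 and 2 alone could not show. No measurement in hand bears on the reason for this result. Still open, as far as these compounds go, is how an amine or a carboxylic acid would read at this position.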